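The source may hold more compounds than are shown below. What is called first, only, known or untested is meant among the compounds shown, and "the series" means these compounds.

Compounds measured in an assay on membranes from HeLa cells for displacement of a labelled ligand from adenosine receptor A3 (Homo sapiens), read by scintillation counting, with a stated time of 180 min, tested at 1 uM; on this read-out higher numbers stand for more inhibition at the one concentration tested (going by the name of the read-out) and lower numbers for less inhibition:
compound 1 `CC1=C(C(N)=O)C(c2ccsc2)NC(=O)N1`: 1%
compound 2 `CC1=C(C(=O)OC2CCCCC2)C(c2ccsc2)NC(=O)N1`: 1%

Compound 2 stands level with compound 1 at the digits shown, and the step of no change at the digits printed from compound 1 to compound 2 (within the scatter) lies within the scatter. Compound 3 `CC1=C(C(=O)OCC2CCC2)C(c2ccsc2)NC(=O)N1` differs from compound 2 by cyclobutylmethyl in place of cyclohexyl on an oxygen next to a carbonyl group. Among the measured compounds shown here, the one measured step, no change at the digits printed from compound 1 to compound 2 (within the scatter), changed a group on the same carbonyl and moved nothing; no measured step touches the alkyl group on this oxygen. Compound 3 is therefore expected to show a number 1 percentage points higher from compound 2 to compound 3 (within the scatter), no step beyond the scatter. Compound 3 is estimated at 2%, between -8% and 12%.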

Compound 3, a percentage reported as inhibition, at one concentration (the size of the read-out at that concentration, not a potency): 2%
Compound 3: middle estimate and measured number agree at the digits printed; the measured number falls inside the stated range.
By their numbers in this assay, from the lowest: compounds 1, 2 and 3 (each within the scatter of the next).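

In this assay, the alkyl group on an oxygen next to a carbonyl group now has a measured step of its own: cyclobutylmethyl in place of cyclohexyl gives a number 1 percentage points higher from compound 2 to compound 3 (within the scatter) and stays within the scatter. Cyclobutylmethoxy in place of amino on a carbonyl carbon likewise gives a number 1 percentage points higher from compound 1 to compound 3 (within the scatter) and adds a second replacement of amino that stays within the scatter. Nothing is available that would explain these numbers.

Still open, going by these compounds, is whether a longer chain on this oxygen, or an alkyl group carrying an amine or a carboxylic acid, would lift the read-out beyond the scatter.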